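Carbamate for Methyl on the Ring Amine: Second Core

This account rests on a few compounds, and the source may have more. Where it says the series, first, only, none or still open, it means among the compounds named here.

Compound 1 `CN1CCc2ccccc2Cc2sccc2CC1`: in an assay on isolated protein for binding affinity to D(1B) dopamine receptor (Homo sapiens), read by radioligand binding, with a stated time of 90 min (on this read-out lower numbers stand for stronger inhibition and higher numbers for weaker inhibition), compound 1 gives 3 nM.
Compound 2 `CN1CCc2ccccc2Cc2sc3ccccc3c2CC1`: in this assay compound 2 gives 1.9 nM.
Compound 3 `CCOC(=O)N1CCc2ccccc2Cc2sccc2CC1`: in this assay compound 3 gives > 1000 nM, which is a limit of the assay and not a number.

Compound 1 and compound 2 differ in their cores; that difference is not broken down here, and their two values lie within the usual scatter of each other. The change from compound 1 to compound 3 is ethoxycarbonyl in place of methyl on an amine nitrogen in a ring and produces an at least 330-fold higher number from compound 1 to compound 3 (2.52 log units; beyond the scatter), a step that rests on (the limit of > 1000 nM in this assay, at which 1 of the 3 values shown sits). Compound 4 `CCOC(=O)N1CCc2ccccc2Cc2sc3ccccc3c2CC1` has not yet been measured. It is related to compound 2 by ethoxycarbonyl in place of methyl on an amine nitrogen in a ring, the same kind of change, made here on a ring that is part of a fused or bridged system of four rings rather than three. The step from compound 2 to compound 4 is expected to be about a 790-fold higher number from compound 2 to compound 4 (2.90 log units; beyond the scatter), because compound 1 showed an at least 330-fold higher number from compound 1 to compound 3 (2.52 log units; beyond the scatter). Compound 4 is estimated at 1500 nM, with a range from 300 nM to 10000 nM.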

Compound 4, inhibition constant: > 1000 nM
Compound 4 was reported as a limit; the forecaster's own chance of this, stated with the estimate: 70%; the middle value does not contradict the limit.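

In this assay compound 4 gives > 1000 nM as a limit of the assay and not a number. Ethoxycarbonyl in place of methyl on the ring nitrogen gives an at least 520-fold higher number from compound 2 to compound 4 (2.72 log units; beyond the scatter) and so weakens binding strongly on the core of compound 2, as it did on the core of compound 1. From the compounds shown here alone, whether the step has the same size on both cores stays unknown: the same change on two cores in this assay, an at least 330-fold higher number (2.52 log units; beyond the scatter) from compound 1 to compound 3 and an at least 520-fold higher number (2.72 log units; beyond the scatter) from compound 2 to compound 4; the limit leaves it open whether they differ.

The compounds shown leave open how other groups on this nitrogen would behave, such as a plain hydrogen, an ethyl or a longer chain. They also leave open whether an acetyl, which keeps the carbonyl but lacks the ethoxy part, would bring the same loss.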